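The source may hold more compounds than are shown below. What is called first, only, known or untested is meant among the compounds shown, and "the series" means these compounds.

Among the measured compounds shown here, in an ADME assay on L6 cells (Rattus norvegicus) for cytotoxicity, with a stated time of 72 h (a lower number here means a stronger inhibitor, a higher number a weaker inhibitor), compound 2 `OC1CC2(N3CCCC3)CC(c3ccccc3)C1C(c1ccccc1)C2` stands at 26800 nM as the lower of the two numbers so far, while compound 1 `O=C(CN1CCCCC1)OC1CC2(N3CCCCC3)CC(c3ccccc3)C1C(c1ccccc1)C2` at 60400 nM lies higher, beyond the scatter. Compound 3 `OC1CC2(N3CCCCC3)CC(c3ccccc3)C1C(c1ccccc1)C2` differs from compound 2 by piperidin-1-yl in place of pyrrolidin-1-yl on a saturated ring carbon with piperidin-1-yl in place of pyrrolidin-1-yl on a saturated ring carbon. For the measured compounds named here, no measured pair shows this change. No step beyond the scatter is expected in this assay and no direction is favoured. The estimated step runs a 1.1-fold lower number from compound 2 to compound 3 (0.03 log units; within the scatter) and is expected to stay small. For compound 3 the estimate is 25000 nM with an expected range of 12000 nM to 52000 nM in this read-out.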

Compound 3, half-maximal inhibitory concentration: 37300 nM
Estimate against measurement, compound 3: 1.5-fold (0.17 log units) below; the measured number falls inside the stated range.
By their numbers in this assay, from the lowest: compounds 2, 3 and 1 (each within the scatter of the next, the first and the last beyond it).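

In this assay, piperidin-1-yl in place of pyrrolidin-1-yl on this saturated ring carbon gives a 1.4-fold higher number from compound 2 to compound 3 (0.14 log units; within the scatter), so this ring change does not separate the two amines in this read-out. Hydrogen in place of ((piperidin-1-yl)methyl)carbonyl on the oxygen gives a 1.6-fold lower number from compound 1 to compound 3 (0.21 log units; within the scatter), so the free hydroxy group and its acylated form are not separated either. Nothing measured here bears on the origin of either step. Still open, on these data alone, is whether morpholine or dimethylamino on this ring carbon, or a longer chain on the oxygen, would give a step beyond the scatter.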